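Aryl ketone piperazine carbamates: tert-butyl for methoxy

The source may report more compounds than this note shows. Statements on the series, on what has been measured and on what is new or still open speak of the compounds shown alone.

Measured compounds:
compound 1, `CCOC(=O)N1CCN(CCCOc2ccc(C(C)=O)cc2)CC1`, 39800 nM
compound 2, `C=C(C)C(=O)c1ccc(OCCCN2CCN(C(=O)OCC)CC2)cc1`, 22400 nM
compound 3, `CCOC(=O)N1CCN(CCCOc2ccc(C(=O)c3ccc(OC)cc3)cc2)CC1`, 8320 nM

All three share one core and differ only in the group on the carbonyl carbon. In an assay on isolated protein for binding affinity to histamine H2 receptor (Homo sapiens) (a higher number here means a weaker inhibitor, a lower number a stronger inhibitor), compound 3 stands lowest of the three numbers, with compound 2 nearest and compound 1 furthest. The measured steps are a 1.8-fold lower number from compound 1 to compound 2 (0.25 log units; within the scatter), a 4.8-fold lower number from compound 1 to compound 3 (0.68 log units; beyond the scatter) and a 2.7-fold lower number from compound 2 to compound 3 (0.43 log units; beyond the scatter). Among the measured compounds shown here, only the step to the 4-methoxyphenyl group moves the number beyond the scatter.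

Compound 4, `CCOC(=O)N1CCN(CCCOc2ccc(C(=O)c3ccc(C(C)(C)C)cc3)cc2)CC1`, is the next member. The change from compound 3 is tert-butyl in place of methoxy on an aromatic carbon. For the measured compounds named here, no measured step touches a group on this outer ring: every step so far exchanged the whole group on the carbonyl carbon, so none bears directly on this change. The two steps that reached compound 3 show that the outer ring itself is what lowered the number, and an exchange of one substituent on that ring is expected to move the number less than that. The estimate for compound 4 is therefore a step of a 1.3-fold lower number from compound 3 to compound 4 (0.12 log units; within the scatter) in this assay, within the scatter, with the direction left open. Compound 4 is expected to give 6300 nM, between 2000 nM and 20000 nM.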

Compound 4, inhibition constant: 1550 nM
Compound 4: the middle estimate sits 4.1-fold (0.61 log units) above what was measured; the measured number lies below the stated range.
By their numbers in this assay, from the lowest: compound 4; then compound 3; then compounds 2 and 1 (each within the scatter of the next).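

The outer ring's substituent matters as well as the ring itself: with the 4-substituted phenyl kept on the carbonyl carbon, tert-butyl in place of methoxy gives a 5.4-fold lower number from compound 3 to compound 4 (0.73 log units; beyond the scatter) in this assay, so this position on the ring responds to a single exchange. Exchanging the whole group on the carbonyl carbon now gives a 14-fold lower number from compound 2 to compound 4 (1.16 log units; beyond the scatter) and a 26-fold lower number from compound 1 to compound 4 (1.41 log units; beyond the scatter), both large, whereas the same exchanges ending in the 4-methoxyphenyl group were modest, so the gain from the outer ring depends on what the ring carries. No measurement at hand accounts for the lower number of compound 4.

The compounds shown hold only methoxy and tert-butyl at this place, so the change in heavy-atom count and the loss of the oxygen move together, and an ethoxy or isopropyl group would be needed to tell them apart. Also open, as far as these compounds go, is how the number responds to an amine or a carboxylic acid at this place, and whether the step from methoxy to tert-butyl holds when the ethyl carbamate or the propyl chain of the shared core is changed.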